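The compounds below may be only part of what the source reports. "The series", "measured", "known", "first", "only" and "open" are said of these compounds alone.

Measured so far: compound 1 `Cc1ccc(C(=O)Nc2cccc(-c3oc4cc(-c5ccc(F)cc5)ccc4c(=O)c3O)c2)cc1` with 6190 nM in a functional assay on HeLa cells (Homo sapiens) for antiproliferative activity, read by CCK-8 assay, with a stated time of 72 h; a lower number here means a stronger inhibitor, a higher number a weaker inhibitor; compound 2 `Cc1cc(C(=O)Nc2cccc(-c3oc4cc(-c5ccc(F)cc5)ccc4c(=O)c3O)c2)ccc1F` with 18900 nM.

Compound 2 stands at the highest of the two numbers in this assay, its nearest neighbour being compound 1, reached by a 3.1-fold higher number from compound 1 to compound 2 (0.48 log units; beyond the scatter).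

Compound 3 `COc1cc(OC)cc(C(=O)Nc2cccc(-c3oc4cc(-c5ccc(F)cc5)ccc4c(=O)c3O)c2)c1` differs from compound 2 by 3,5-dimethoxyphenyl in place of 4-fluoro-3-methylphenyl on a carbonyl carbon. Within the data shown here, the one measured step that bears on a change at this carbonyl carbon is a 3.1-fold higher number from compound 1 to compound 2 (0.48 log units; beyond the scatter), a modest shift. For the step to compound 3 a shift of comparable size is therefore expected, in either direction; compound 3 is estimated at 10000 nM, range 3000 nM to 35000 nM, meaning an expected 1.9-fold lower number from compound 2 to compound 3 (0.28 log units; within the scatter).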

Compound 3, half-maximal inhibitory concentration: 2700 nM
Beside the measured number, compound 3's estimate is 3.7-fold (0.57 log units) above it; the measured number lies below the stated range.
By their numbers in this assay, from the lowest: compound 3; then compound 1; then compound 2.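

In this assay the aryl group on this carbonyl carbon can move the number down as well as up: 3,5-dimethoxyphenyl in place of 4-fluoro-3-methylphenyl gives a 7.0-fold lower number from compound 2 to compound 3 (0.85 log units; beyond the scatter) and in place of 4-methylphenyl gives a 2.3-fold lower number from compound 1 to compound 3 (0.36 log units; beyond the scatter) in the same direction. Compound 3 therefore has the lowest number of the three, and both of its steps lie beyond the scatter. Nothing available accounts for this gain. Still open, from the compounds shown here alone, is whether one methoxy group would serve as well as two, and how a dimethylamino group or a carboxylic acid on this phenyl ring would compare.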